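The compounds below may be only part of what the source reports. "The series", "measured", "known", "first", "only" and "open" are said of these compounds alone.

Measured in a functional assay on A549 cells (Homo sapiens) for cytotoxicity, read by MTT assay, with a stated time of 72 h; on this read-out lower numbers stand for stronger inhibition and higher numbers for weaker inhibition:
- compound 1 `COc1ccc(/C=N/NC(=O)Nc2cc3c(Nc4ccc(F)c(Cl)c4)ncnc3cc2O[C@H]2CCOC2)c(OC)c1OC`: 25200 nM
- compound 2 `COc1cc2ncnc(Nc3ccc(F)c(Cl)c3)c2cc1NC(=O)N/N=C/c1ccc(F)cc1`: 26600 nM
- compound 3 `COc1ccc(/C=N/NC(=O)Nc2cc3c(Nc4ccc(F)c(Cl)c4)ncnc3cc2OC)cc1`: 28100 nM

In this assay compound 3 gives 28100 nM, within the scatter of both other compounds, so the three values do not separate. The next compound is compound 4 `COc1cc2ncnc(Nc3ccc(F)c(Cl)c3)c2cc1NC(=O)N/N=C/c1ccc(OC)c(OC)c1OC`, which has 2,3,4-trimethoxyphenyl in place of 4-methoxyphenyl on a carbon with a double bond to nitrogen. Within the data shown here, the one measured step that bears on this is methoxy in place of fluoro on an aromatic carbon, a 1.1-fold higher number from compound 2 to compound 3 (0.02 log units; within the scatter), and it stays within the scatter. The 2,3,4-trimethoxyphenyl group also occurs in compound 1 at 25200 nM, although the core of that compound carries a different substituent, and this value too lies within the scatter of the others. No change beyond the scatter is therefore expected in this assay. The expected step is a 1.1-fold lower number from compound 3 to compound 4 (0.03 log units; within the scatter). For compound 4 the estimated value is 26000 nM, with an expected range from 14000 nM to 45000 nM.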

Compound 4, half-maximal inhibitory concentration: 32800 nM
Compound 4: middle estimate off by 1.3-fold (0.10 log units), on the low side; measured number inside the range.
By their numbers in this assay, from the lowest: compounds 1, 2, 3 and 4 (each within the scatter of the next).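

In this assay the step to 2,3,4-trimethoxyphenyl on the carbon with a double bond to nitrogen gives a 1.2-fold higher number from compound 3 to compound 4 (0.07 log units; within the scatter) from the 4-methoxyphenyl compound and a 1.2-fold higher number from compound 2 to compound 4 (0.09 log units; within the scatter) from the 4-fluorophenyl compound, so three different groups at this position on the same core do not separate. With 2,3,4-trimethoxyphenyl held constant, methyl in place of oxolan-3-yl on the oxygen gives a 1.3-fold higher number from compound 1 to compound 4 (0.11 log units; within the scatter), which shows that this second place also yields no change beyond the scatter with this group present. Nothing available here explains why these values stay together.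

The compounds shown leave open whether an amine or a carboxylic acid on that aromatic ring would give a step beyond the scatter. The same question stands for a longer chain on the oxygen in place of methyl.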